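This account rests on a few compounds, and the source may have more. Where it says the series, first, only, none or still open, it means among the compounds named here.

Readings so far in an ADME assay on microsomes from liver (Mus musculus) for metabolic stability, with a stated time of 10 min (a higher number here means that more of the compound is left, a lower number that less of the compound is left), are these
compound 1 `CCC[C@]1(C(=O)N2CC[C@](c3ccc(C(F)(C(F)(F)F)C(F)(F)F)cc3)(S(=O)(=O)c3ccc(F)cc3)C2)CC[C@H](C(=O)O)CC1` gives "not determined" (no result reported)
compound 2 `O=C(O)C12CCC(C(=O)N3CC[C@](c4ccc(C(F)(C(F)(F)F)C(F)(F)F)cc4)(S(=O)(=O)c4ccc(F)cc4)C3)(CC1)OC2` gives 94%

Compound 1 offers no number, so compound 2 stands alone and cannot be ranked against anything. Within the data shown here, no measured pair gives a step to calibrate against. Compound 3 `NC(=O)[C@H]1CC[C@H](C(=O)N2CC[C@](c3ccc(C(F)(C(F)(F)F)C(F)(F)F)cc3)(S(=O)(=O)c3ccc(F)cc3)C2)CC1` is still unmeasured and shares the core of compound 2. The change is a group of 9 heavy atoms (7 carbon, 1 nitrogen, 1 oxygen; one six-membered non-aromatic ring of carbon only) in place of a group of 11 heavy atoms (8 carbon, 3 oxygen; one six-membered non-aromatic ring of carbon only, one six-membered non-aromatic ring with 1 hetero atom), on a carbonyl carbon, with 4-carbamoylcyclohexyl entering on a carbonyl carbon. With compound 2 at 94% there is little room for a rise, so any real movement is expected to be downward. The expected move, a number 12 percentage points lower from compound 2 to compound 3 (beyond the scatter), is a modest fall, only slightly beyond the usual scatter and uncertain in size. For compound 3 the estimated value in this assay is 82%, with an expected range from 62% to 97% for the measurement.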

Compound 3, percent of the compound remaining: 100%
The estimate for compound 3 lay 18 percentage points below the measured number; measured number above the stated range.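

On the carbonyl carbon whose other neighbours are an amide-type nitrogen in a ring, 4-carbamoylcyclohexyl in place of the group carried by compound 2 gives a number 6 percentage points higher from compound 2 to compound 3 (within the scatter) in this assay. Among these compounds, this is the first readable step at this place, and it shows that the second, hetero-atom ring of the leaving group can be absent without a change beyond the scatter in this read-out. No measurement at hand bears on the reason for this result.

From the compounds shown here alone, with both compounds close to the whole of the compound remaining, it stays open whether any group at this place lowers the reading in this assay. Also open, going by these compounds, is whether an amine or a nitrile in place of the carbamoyl group on the cyclohexyl ring would read the same.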